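One Stereocentre Flipped in the Trifluoromethyl Carbamate Series

The compounds below may be only part of what the source reports. "The series", "measured", "known", "first", "only" and "open" are said of these compounds alone.

Compound 1 `COc1cnc(O[C@@H]2C[C@@H](C(=O)N[C@]3(C(=O)NS(=O)(=O)C4CC4)C[C@H]3C3CC3)N(C(=O)[C@@H](NC(=O)OC(C)C)C(C)(C)C)C2)c2cc(Cl)ccc12`: 0.583 h
Compound 2 `COc1cnc(O[C@@H]2C[C@@H](C(=O)N[C@]3(C(=O)NS(=O)(=O)C4CC4)C[C@H]3C3CC3)N(C(=O)[C@@H](NC(=O)O[C@@H]3C[C@@H]4C[C@@H]4C3)C(C)(C)C)C2)c2cc(Cl)ccc12`: 1.97 h
Compound 3 `COc1cnc(O[C@@H]2C[C@@H](C(=O)N[C@]3(C(=O)NS(=O)(=O)C4CC4)C[C@H]3C3CC3)N(C(=O)[C@@H](NC(=O)O[C@@H](C)C(F)(F)F)C(C)(C)C)C2)c2cc(Cl)ccc12`: > 3.33 h (a limit)

In an ADME assay on liver (Homo sapiens) for metabolic stability, using microsomes (on this read-out lower numbers stand for a shorter-lived compound and higher numbers for a longer-lived compound), compound 3 gives > 3.33 h, which is a limit of the assay and not a number. The measurements show an at least 5.7-fold higher number from compound 1 to compound 3 (0.75 log units; beyond the scatter). Against the remaining compound they show an at least 1.6-fold higher number from compound 2 to compound 3 (0.22 log units; that floor lies within the scatter).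

Compound 4 `COc1cnc(O[C@@H]2C[C@@H](C(=O)N[C@]3(C(=O)NS(=O)(=O)C4CC4)C[C@H]3C3CC3)N(C(=O)[C@@H](NC(=O)O[C@H](C)C(F)(F)F)C(C)(C)C)C2)c2cc(Cl)ccc12` keeps every atom and bond of compound 3. The change is the two compounds have the same atoms and bonds and differ only in configuration as drawn: 1 of 6 stereo elements differ; a stereocentre at a saturated chain carbon is drawn S in compound 3 and R in compound 4. The 1-(trifluoromethyl)ethyl group therefore stays in place, and only its drawn configuration differs.

Within the data shown here, no measured step changes configuration alone, so the evidence is indirect. The nearest steps are exchanges of a whole group on an oxygen next to a carbonyl group. They are a 3.4-fold higher number from compound 1 to compound 2 (0.53 log units; beyond the scatter) and an at least 5.7-fold higher number from compound 1 to compound 3 (0.75 log units; beyond the scatter). Both exchange the group itself, which compound 4 does not do, so a step of that size is not expected here, and the data give no direction for a change of configuration. The expected step is an at least 1.0-fold lower number from compound 3 to compound 4 (0.01 log units; that floor lies within the scatter), and no shift beyond the scatter is anticipated in either direction.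

The estimate for compound 4 is 3.2 h, with an expected range from 1.5 h to 6.5 h.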

Compound 4, half-life: 2.12 h
The estimate for compound 4 lay 1.5-fold (0.18 log units) above the measured number; the measured number falls inside the stated range.
By their numbers in this assay, from the lowest: compound 1; then compounds 2 and 4 (each within the scatter of the next). At a limit, above all of these: compound 3.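

In this assay, among these compounds, drawing the stereocentre of the 1-(trifluoromethyl)ethyl group as R in place of S gives an at least 1.5-fold lower number from compound 3 to compound 4 (0.19 log units; that floor lies within the scatter), the first reading of configuration alone at this position. Compound 3 stands at > 3.33 h, which is a limit of the assay and not a number, so this step has only a floor and no measured size: the limit of > 3.33 h in this assay, at which 1 of the 4 values shown sits. With the R form, the difference from isopropyl still holds beyond the scatter, at a 3.6-fold higher number from compound 1 to compound 4 (0.56 log units; beyond the scatter), while the exchange with the ring-bearing group of six carbon atoms shows no separation, at a 1.1-fold higher number from compound 2 to compound 4 (0.03 log units; within the scatter).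

Among the compounds shown here, how far apart the two configurations truly lie stays open, as does whether the stereocentre matters at all in this assay, given that the one pair that isolates it rests on a limit. The compounds shown also leave open how a longer chain such as 1-(trifluoromethyl)propyl, or a difluoromethyl group in place of trifluoromethyl, would read at this position in either configuration.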